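Trading the Ester Branch of the Ring Nitrogen Carbonyl

This account rests on a few compounds, and the source may have more. Where it says the series, first, only, none or still open, it means among the compounds named here.

The three measured compounds, all read in a functional assay on isolated protein for inhibition of Glucose-dependent insulinotropic receptor (Rattus norvegicus), read by HTRF and cAMP accumulation; a lower number here means that less compound is needed, a higher number that more compound is needed for the effect:

compound 1, `Cc1nc(S(C)(=O)=O)ccc1Oc1ncnc(OC2CCN(C(=O)OC3CCC3)CC2)c1F`, gives 167 nM
compound 2, `Cc1nc(S(C)(=O)=O)ccc1Oc1ncnc(OC2CCN(C(=O)OC(C)F)CC2)c1F`, gives 315 nM
compound 3, `Cc1nc(S(C)(=O)=O)ccc1Oc1ncnc(OC2CCN(C(=O)O[C@H](C)C(F)(F)F)CC2)c1F`, gives 110 nM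

Compound 3 has the lowest of the three numbers. Its nearest neighbour is compound 1, and the difference between them, a 1.5-fold lower number from compound 1 to compound 3 (0.18 log units; within the scatter), is within the scatter, so the two cannot be ordered. Against compound 2 the gap is clearer: a 2.9-fold lower number from compound 2 to compound 3 (0.46 log units; beyond the scatter). The third measured step, a 1.9-fold higher number from compound 1 to compound 2 (0.28 log units; within the scatter), is also within the scatter. All three steps vary only the group on the oxygen next to the carbonyl, and none of them moves the number far.

Compound 4, `Cc1nc(S(C)(=O)=O)ccc1Oc1ncnc(OC2CCN(C(=O)C(F)(F)F)CC2)c1F`, goes further: trifluoromethyl in place of 1-(trifluoromethyl)ethoxy on a carbonyl carbon. Here the oxygen branch is removed altogether rather than exchanged, and no measured pair speaks to that kind of change directly. What the measured steps do show is that this end of the molecule tolerates variation without large swings. The expectation is therefore a small rise in the number, a 2.4-fold higher number from compound 3 to compound 4 (0.37 log units; beyond the scatter), though with wide uncertainty. Compound 4 is estimated at 260 nM in this assay, with a likely range from 90 nM to 750 nM.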

Compound 4, half-maximal effective concentration: 880 nM
Estimate against measurement, compound 4: 3.4-fold (0.53 log units) below; the whole stated range lies below it.
By their numbers in this assay, from the lowest: compounds 3, 1 and 2 (each within the scatter of the next, the first and the last beyond it); then compound 4.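

Among the earlier compounds, the group on the carbonyl carbon was only exchanged for another group joined through oxygen, and in this assay those exchanges moved the number little. Replacing 1-(trifluoromethyl)ethoxy with trifluoromethyl gives the largest step among these compounds, an 8.0-fold higher number from compound 3 to compound 4 (0.90 log units; beyond the scatter). The rise also holds against the other two oxygen-linked groups, with a 5.3-fold higher number from compound 1 to compound 4 (0.72 log units; beyond the scatter) where cyclobutyloxy leaves and a 2.8-fold higher number from compound 2 to compound 4 (0.45 log units; beyond the scatter) where the 1-fluoroethyl group and its oxygen leave, so this position accepts exchange among the three oxygen-linked groups more readily than this change, and none of the four compounds goes against that reading. Nothing available here accounts for the rise.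

Compound 4 loses the oxygen and also carries a smaller group, so the compounds shown do not separate the two changes. On these data alone, how the number would read with a cyclobutyl group joined directly to the carbonyl carbon, or with an amine such as dimethylamine in that place, remains open, and such compounds could show whether the oxygen itself matters here.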